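The source may report more compounds than this note shows. Statements on the series, on what has been measured and on what is new or still open speak of the compounds shown alone.

Measured compounds:
compound 1 `CC(C)=CCC[C@]1(C)/C=C/[C@@H](OC(=O)C=C(C)C)[C@](C)(O)/C=C/C(=O)/C(CCl)=C\C1`, 160 nM
compound 2 `CC(C)=CCC[C@]1(C)/C=C/[C@@H](OC(=O)C=C(C)C)[C@](C)(O)CCC(=O)/C(CO)=C\C1`, > 40000 nM
compound 3 `CC(C)=CCC[C@]1(C)/C=C/[C@@H](OC(=O)C=C(C)C)[C@](C)(O)/C=C/[C@H](O)/C(CO)=C\C1`, > 40000 nM

Within the data shown here, in a functional assay on HL-60 cells (Homo sapiens) for antiproliferative activity, read by MTT assay, with a stated time of 48 h (a lower number here means a stronger inhibitor, a higher number a weaker inhibitor), compound 1 gives 160 nM, the only actual number among the three measured compounds. For compound 2 this assay reports only a limit, > 40000 nM. For compound 3 this assay likewise reports only a limit, > 40000 nM. Among the measured compounds shown here, both sit at the limit of > 40000 nM in this assay, at which 2 of the 3 values shown sit, so no step size can be read between compound 1 and either of them beyond the fact that compound 1 is the one with a real value.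

Compound 4 `CO/N=C/C1=C/C[C@](C)(CCC=C(C)C)/C=C/[C@@H](OC(=O)C=C(C)C)[C@](C)(O)/C=C/C1=O` has not been measured. It differs from compound 1 in one place: a group of 4 heavy atoms (2 carbon, 1 nitrogen, 1 oxygen; no ring) in place of a group of 2 heavy atoms (1 carbon, 1 chlorine; no ring), on a double-bonded ring carbon. The rest of the shared core, including the conjugated ketone of compound 1, stays as it is.

For the measured compounds named here, with no measured step of this kind to lean on, the expectation for compound 4 is a moderate loss, estimated as a 9.4-fold higher number from compound 1 to compound 4 (0.97 log units; beyond the scatter), reaching beyond the usual scatter but staying well short of the limit. Compound 4 is therefore expected to give about 1500 nM, with a likely range from 250 nM to 10000 nM.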

Compound 4, half-maximal inhibitory concentration: 4760 nM
Estimate against measurement, compound 4: 3.2-fold (0.50 log units) below, within the range that was stated.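

In this assay, this is the first step shown at this double-bonded ring carbon with the rest of the shared core unchanged: replacing the chloromethyl group with the group of 4 heavy atoms gives a 30-fold higher number from compound 1 to compound 4 (1.47 log units; beyond the scatter). Activity therefore depends strongly on the group at this position, and the change is large, yet chloromethyl is not the only group here that gives a measured value. Compound 4 has a real number rather than a limit, so this replacement weakens the compound without taking it to the ceiling of the assay: the limit of > 40000 nM in this assay, at which 2 of the 4 values shown sit.

With only one replacement at this position, the compounds shown cannot tell which feature of either group accounts for the step. Going by these compounds, whether a plain methyl, an aminomethyl or a carboxylic acid here would stay close to compound 1 at 160 nM remains open.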